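Plasma Half-Life of Aspirin Diesters with Varied Aryl Groups

The compounds below may be only part of what the source reports. "The series", "measured", "known", "first", "only" and "open" are said of these compounds alone.

In an ADME assay on a cell-free system (plasma, Homo sapiens) for metabolic stability, with Plasma (Rattus norvegicus) as the target, read by HPLC, at pH 7.4 (a higher number here means that the compound lasts longer, a lower number that the compound disappears faster), compound 1 `CC(=O)Oc1ccccc1C(=O)O[C@H]1CO[C@H]2[C@@H]1OC[C@H]2OC(=O)c1cccc(O)c1` gives 0.0183 h, the lowest of the three numbers recorded. Compound 2 `CC(=O)Oc1ccccc1C(=O)O[C@H]1CO[C@H]2[C@@H]1OC[C@H]2OC(=O)c1ccc(C)cc1` gives 0.105 h and compound 3 `CC(=O)Oc1ccccc1C(=O)O[C@H]1CO[C@H]2[C@@H]1OC[C@H]2OC(=O)c1cnccc1Cl` gives 0.0642 h, so that compound 1 sits a 5.7-fold higher number from compound 1 to compound 2 (0.76 log units; beyond the scatter) and a 3.5-fold higher number from compound 1 to compound 3 (0.55 log units; beyond the scatter) below the others, while a 1.6-fold lower number from compound 2 to compound 3 (0.21 log units; within the scatter) keeps those two within the scatter of each other.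

Compound 4 `CC(=O)Oc1ccccc1C(=O)O[C@H]1CO[C@H]2[C@@H]1OC[C@H]2OC(=O)c1cc(C)nc(Cl)c1` has not been measured. It differs from compound 1 in one place: 2-chloro-6-methylpyridin-4-yl in place of 3-hydroxyphenyl on a carbonyl carbon. Both measured steps away from compound 1 bear on this change, since each also removes the 3-hydroxyphenyl from the carbonyl carbon: a 5.7-fold higher number from compound 1 to compound 2 (0.76 log units; beyond the scatter) and a 3.5-fold higher number from compound 1 to compound 3 (0.55 log units; beyond the scatter). Compound 3 is the closer comparison because its entering group is also a chlorinated pyridinyl, a 3.5-fold higher number from compound 1 to compound 3 (0.55 log units; beyond the scatter). A rise of similar size, beyond the scatter, is therefore expected for compound 4, a 3.8-fold higher number from compound 1 to compound 4 (0.58 log units; beyond the scatter). The half-life of compound 4 in this assay is estimated at 0.07 h, with a range from 0.03 h to 0.17 h.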

Compound 4, half-life: 0.0193 h
Beside the measured number, compound 4's estimate is 3.6-fold (0.56 log units) above it; measured number below the stated range.
By their numbers in this assay, from the lowest: compounds 1 and 4 (each within the scatter of the next); then compounds 3 and 2 (each within the scatter of the next).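

Taking the 3-hydroxyphenyl off this carbonyl carbon does not in itself give a longer-lived compound in this assay: a 1.1-fold higher number from compound 1 to compound 4 (0.02 log units; within the scatter) leaves the two level. A chlorinated pyridinyl group here does not ensure a longer half-life either, as the two such groups stand apart, a 3.3-fold lower number from compound 3 to compound 4 (0.52 log units; beyond the scatter), and the 2-chloro-6-methylpyridin-4-yl group also falls short of the 4-methylphenyl group, a 5.4-fold lower number from compound 2 to compound 4 (0.74 log units; beyond the scatter). Nothing available accounts for this gap between the two chlorinated pyridinyl groups.

The compounds shown do not separate the contributions of the chlorine, the methyl and the ring nitrogen of the 2-chloro-6-methylpyridin-4-yl group. They also leave open how an aryl group bearing an amine or a carboxylic acid, or a longer alkyl chain in place of the ring, would behave on this carbonyl carbon in this assay.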